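The compounds below may be only part of what the source reports. "The series", "measured", "known", "first", "only" and "open" are said of these compounds alone.

Compound 3 `CCc1nc2c(C)cc(C)nc2n1Cc1ccc(OC(C(=O)O)c2ccccc2)c(C(C)C)c1` stands at the weak end of the three compounds measured in an assay on Midbrain with Type-2 angiotensin II receptor (Rattus norvegicus) as the target; a higher number here means a weaker inhibitor, a lower number a stronger inhibitor: compound 3 gives 3300 nM. Compound 1 `CCc1nc2c(C)cc(C)nc2n1Cc1ccc(OC(C(=O)O)c2ccccc2)c(Cl)c1` gives 720 nM in this assay, and compound 2 `CCCCc1cc(Cn2c(CC)nc3c(C)cc(C)nc32)ccc1OC(C(=O)O)c1ccccc1` gives 140 nM in this assay. Both steps that lead to compound 3 run the same way, a 4.6-fold higher number from compound 1 to compound 3 (0.66 log units; beyond the scatter) and a 24-fold higher number from compound 2 to compound 3 (1.37 log units; beyond the scatter), while a 5.1-fold lower number from compound 1 to compound 2 (0.71 log units; beyond the scatter). Compound 4 `CCOc1cc(Cn2c(CC)nc3c(C)cc(C)nc32)ccc1OC(C(=O)O)c1ccccc1` is reached by ethoxy in place of isopropyl on an aromatic carbon; the group that enters matches the one that leaves in its count of heavy atoms but brings one hydrogen-bond acceptor. For the measured compounds named here, no measured step exchanges an alkyl group for an alkoxy group on this aromatic carbon, so the measured steps bear on the change only indirectly: the two other groups seen there, chloro in compound 1 and butyl in compound 2, both give lower numbers in this assay than the isopropyl of compound 3, which is the least favourable of the three. A return toward the values of compound 1 and compound 2 is expected, with wide uncertainty. Compound 4 is therefore estimated at 900 nM, within 300 nM to 3000 nM. This estimate means an expected step of a 3.7-fold lower number from compound 3 to compound 4 (0.56 log units; beyond the scatter).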

Compound 4, half-maximal inhibitory concentration: 1200 nM
Compound 4: middle estimate off by 1.3-fold (0.12 log units), on the low side, within the range that was stated.
By their numbers in this assay, from the lowest: compound 2; then compounds 1 and 4 (each within the scatter of the next); then compound 3.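

In this assay, the exchange of isopropyl for ethoxy, which carries the same count of heavy atoms and adds one hydrogen-bond acceptor, gives a 2.8-fold lower number from compound 3 to compound 4 (0.44 log units; beyond the scatter), so this aromatic carbon distinguishes between groups that match in heavy-atom count. Ethoxy does not reach the butyl result, with an 8.6-fold higher number from compound 2 to compound 4 (0.93 log units; beyond the scatter), while a 1.7-fold higher number from compound 1 to compound 4 (0.22 log units; within the scatter) leaves ethoxy and chloro indistinguishable. No supporting measurement accounts for these differences.

The compounds shown leave open whether the gap to butyl follows chain length or the oxygen, a question that a butoxy or propyl group at this position would address. They also leave open how an amine or a hydroxyl group on this carbon would compare with ethoxy.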